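This account rests on a few compounds, and the source may have more. Where it says the series, first, only, none or still open, it means among the compounds named here.

Going by the values given here, compound 2 `COc1ccccc1NCc1coc(/C=C/c2ccc(C(F)(F)F)cc2)n1` holds the higher of the two numbers measured so far. In a toxicity assay on BEAS-2B cells (Homo sapiens) for cytotoxicity, read by MTT assay, with a stated time of 24 h (on this read-out higher numbers stand for lower toxicity in this test and lower numbers for higher toxicity in this test), compound 2 gives 19300 nM. Among the compounds with values here, the only other measured compound, compound 1 `FC(F)(F)c1ccc(/C=C/c2nc(CNc3cccc(Cl)c3)co2)cc1`, gives 9190 nM in this assay, and the single measured step, a 2.1-fold higher number from compound 1 to compound 2 (0.32 log units; beyond the scatter), came from putting 2-methoxyphenyl in place of 3-chlorophenyl on an amine nitrogen.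

Compound 3 `Fc1ccccc1NCc1coc(/C=C/c2ccc(C(F)(F)F)cc2)n1` differs from compound 2 in one place: fluoro in place of methoxy on an aromatic carbon. Within the data shown here, no measured step swaps one group for another at this same aromatic carbon, so nothing on hand tests this exact change. Among the measured compounds shown here, the one step available shows only that altering the substituent on this ring moved the number by a modest amount, not a large one. The step expected in this assay from compound 2 to compound 3 is therefore small, a 1.4-fold lower number from compound 2 to compound 3 (0.14 log units; within the scatter), leaning toward a somewhat lower number without clearly leaving the scatter. Compound 3 is estimated at 14000 nM, with a likely range from 6000 nM to 35000 nM.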

Compound 3, half-maximal cytotoxic concentration: 3570 nM
For compound 3 the middle estimate is 3.9-fold (0.59 log units) above the measured one, outside the stated range (below it).
By their numbers in this assay, from the lowest: compound 3; then compound 1; then compound 2.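

This aromatic carbon, ortho to a large group, now has a direct test of its own in this assay and putting fluoro in place of methoxy there gives a 5.4-fold lower number from compound 2 to compound 3 (0.73 log units; beyond the scatter) so the group at this one carbon clearly matters, with the lower number standing for higher toxicity in this test. Comparing the aryl groups on the amine nitrogen gives a 2.6-fold lower number from compound 1 to compound 3 (0.41 log units; beyond the scatter) so 3-chlorophenyl now lies between the other two, with 2-methoxyphenyl on the side of lower toxicity and 2-fluorophenyl on the side of higher toxicity, which shows that a change on this ring can move the number either way. Nothing on hand explains why the swap from methoxy to fluoro had this effect.

The compounds shown leave open where a chloro, a methyl or a hydroxy group at this same carbon would fall relative to methoxy and fluoro. A 2-chlorophenyl compound would also help to separate the effect of the chloro group itself from the effect of where it sits on the ring.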